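Replacing naphthalen-1-yl on a weakly active compound

The compounds below may be only part of what the source reports. "The series", "measured", "known", "first", "only" and "open" are said of these compounds alone.

In a functional assay on PC-3 cells (Homo sapiens) for inhibition, read by sulforhodamine B assay, with a stated time of 48 h, tested at 50 uM (on this read-out higher numbers stand for more inhibition of growth at the one concentration tested and lower numbers for less inhibition of growth), compound 1 `COc1cc(/C=C/C(=O)/C=C/c2cccc3ccccc23)ccc1OCc1cn(CCCOc2cc(=O)oc3ccccc23)nn1` gives 8% and so has only a small effect at the single concentration tested. Compound 2 `COc1cccc(/C=C/C(=O)/C=C/c2ccc(OCc3cn(CCOc4cc(=O)oc5ccccc45)nn3)c(OC)c2)c1` gives 13% which lies within the scatter of compound 1, and compound 3 `COc1cc(/C=C/C(=O)/C=C/c2cccc3ccccc23)ccc1OCc1cn(CCCCOc2cc(=O)oc3ccccc23)nn1` is recorded as "not active" (no number reported) without a number.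

Compound 4 `COc1ccc(/C=C/C(=O)/C=C/c2ccc(OCc3cn(CCCOc4cc(=O)oc5ccccc45)nn3)c(OC)c2)cc1OC` has not been measured yet. Its change from compound 1 is 3,4-dimethoxyphenyl in place of naphthalen-1-yl on a double-bonded chain carbon bound to a double-bonded chain carbon and it sits on a double-bonded chain carbon bound to a double-bonded chain carbon.

Going by the values given here, no two measured compounds differ in just one place, so the size of this step in this assay cannot be read directly. Compound 2 also lacks the naphthalen-1-yl group and gives 13% in the same range as compound 1, so no change beyond the scatter is expected. The expected change is a number 4 percentage points higher from compound 1 to compound 4 (within the scatter) and this estimate stays within the usual scatter. For compound 4 the estimated value is 12% (expected range 3% to 25%).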

Compound 4, percent growth inhibition at one concentration: 9%
The estimate for compound 4 lay 3 percentage points above the measured number; low and high end bracket the measured number.
By their numbers in this assay, from the lowest: compounds 1, 4 and 2 (each within the scatter of the next).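

In this assay, going by these compounds alone, putting 3,4-dimethoxyphenyl in place of naphthalen-1-yl gives a number 1 percentage points higher from compound 1 to compound 4 (within the scatter), the first comparison here in which only one place differs. At this position, on a double-bonded chain carbon bound to a double-bonded chain carbon, a group with two six-membered aromatic rings and no hydrogen-bond acceptors and a group with one such ring and two acceptors cannot be told apart in this read-out. Nothing available explains this result.

As far as these compounds go, whether a group of a different kind at this position, such as an amine or a carboxylic acid, would lift growth inhibition clear of the scatter remains open. Also open, from the compounds shown here alone, is whether compound 1 and compound 4 would separate in a full concentration series rather than at one concentration.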